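What happens when the methoxy leaves compound 1

This account rests on a few compounds, and the source may have more. Where it says the series, first, only, none or still open, it means among the compounds named here.

Compound 1 (`COc1nc2ccccc2n1C(=O)NCCCCc1ccccc1`) has been studied in an ADME assay on a cell-free system (plasma, Mus musculus) for metabolic stability, read by HPLC, with a stated time of 120 min, tested at 2 uM; on this read-out higher numbers stand for a longer-lived compound and lower numbers for a shorter-lived compound. There compound 1 gives > 2 h, which is a limit of the measurement and not a number. Compound 2 (`O=C(NCCCCc1ccccc1)n1ncc2ccccc21`) gives > 2 h, which is also a limit. The evidence so far is therefore (the limit of > 2 h in this assay, at which 2 of the 2 values shown sit). Among the measured compounds shown here, neither compound has an exact half-life, and no measured step between two compounds is available as a guide.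

Compound 3 (`O=C(NCCCCc1ccccc1)n1cnc2ccccc21`) has not yet been measured. It is compound 1 with hydrogen in place of methoxy on an aromatic carbon, between two ring nitrogen atoms: hydrogen in place of methoxy on an aromatic carbon. Since only limits are available, the size of the change in this assay cannot be read from earlier results. The cautious expectation is a small shortening of the half-life, perhaps none beyond the scatter. The estimated step is an at least 1.3-fold lower number from compound 1 to compound 3 (0.12 log units; that floor lies within the scatter). The half-life expected for compound 3 is 1.5 h, with an estimated range of 0.5 h to 4 h.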

Compound 3, half-life: > 2 h
Compound 3 ended at the assay's limit (the forecaster's own chance of this, stated with the estimate: 45%); at least 1.3-fold (0.12 log units) between middle value and limit.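

In this assay compound 3 gives > 2 h, which is a limit of the measurement and not a number. Among the compounds shown here, compound 1 also sits at a limit, and no step from compound 1 to compound 3 can be read. The compounds shown leave open how long each one really lasts, and whether hydrogen in place of methoxy changes that at all: the limit of > 2 h in this assay, at which 3 of the 3 values shown sit.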